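The source may report more compounds than this note shows. Statements on the series, on what has been measured and on what is new or still open speak of the compounds shown alone.

Measured in a functional assay on HL-60 cells (Homo sapiens) for inhibition, read by CCK-8 assay, with a stated time of 48 h; on this read-out lower numbers stand for stronger inhibition and higher numbers for weaker inhibition:
- Compound 1 `O=C(NCCNS(=O)(=O)c1ccc(-c2ccccc2O[C@H]2CC[C@H](O)CC2)s1)Nc1cc(C(F)(F)F)cc(C(F)(F)F)c1`: 7100 nM
- Compound 2 `O=C(NCCNS(=O)(=O)c1ccc(-c2ccccc2O[C@H]2CC[C@@H](O)CC2)s1)Nc1cc(C(F)(F)F)cc(C(F)(F)F)c1`: 3100 nM
- Compound 3 `Nc1ccc(Oc2ccccc2-c2ccc(S(=O)(=O)NCCNC(=O)Nc3cc(C(F)(F)F)cc(C(F)(F)F)c3)s2)cc1`: > 50000 nM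

The entry for compound 3 is a limit of the assay, not a number. Even so, compound 3 is the weakest of the three, as an at least 7.0-fold higher number from compound 1 to compound 3 (0.84 log units; beyond the scatter) and an at least 16-fold higher number from compound 2 to compound 3 (1.20 log units; beyond the scatter) show. Both of these steps put 4-aminophenyl in place of 4-hydroxycyclohexyl on an oxygen on an aromatic ring, so this place clearly matters. By contrast, a 2.3-fold lower number from compound 1 to compound 2 (0.36 log units; beyond the scatter) involves only a change in configuration.

Compound 4 `O=C(NCCNS(=O)(=O)c1ccc(-c2ccccc2Oc2ccc(O)c(O)c2)s1)Nc1cc(C(F)(F)F)cc(C(F)(F)F)c1` changes the same place again: 3,4-dihydroxyphenyl in place of 4-aminophenyl on an oxygen on an aromatic ring. In words, 3,4-dihydroxyphenyl replaces 4-aminophenyl. Among the measured compounds shown here, no measured step exchanges one aromatic group for another, so any forecast is loose. Compound 4 regains hydroxyl groups, as found in compound 1 at 7100 nM and compound 2 at 3100 nM, so a partial move towards those values seems plausible. The expected change is an at least 4.1-fold lower number from compound 3 to compound 4 (0.61 log units; beyond the scatter), in the direction of stronger inhibition. For compound 4 the estimated value is 12000 nM, with an expected range from 3000 nM to 50000 nM.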

Compound 4, half-maximal inhibitory concentration: 10500 nM
Beside the measured number, compound 4's estimate is 1.1-fold (0.06 log units) above it, and the stated range covers the measured number.
By their numbers in this assay, from the lowest: compound 2; then compounds 1 and 4 (each within the scatter of the next). At a limit, above all of these: compound 3.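

The entry for compound 3 is a limit of the assay and not a number: the limit of > 50000 nM in this assay, at which 1 of the 4 values shown sits. With an aromatic ring kept on this oxygen, exchanging 4-aminophenyl for 3,4-dihydroxyphenyl gives an at least 4.7-fold lower number from compound 3 to compound 4 (0.67 log units; beyond the scatter), so an aromatic ring here does not by itself rule out measurable inhibition, and the groups on that ring make a clear difference. The comparison with the 4-hydroxycyclohexyl compounds splits by configuration: a 1.5-fold higher number from compound 1 to compound 4 (0.17 log units; within the scatter), whereas a 3.4-fold higher number from compound 2 to compound 4 (0.53 log units; beyond the scatter).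

Going by these compounds, whether a plain phenyl group or a methoxyphenyl group on this oxygen would behave like compound 4 stays open, as does which of the two hydroxyl groups matters. On these data alone, the full size of the step from compound 3 also stays open.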